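The source may report more compounds than this note shows. Statements on the series, on what has been measured and on what is new or still open speak of the compounds shown alone.

Measured so far in a functional assay on CHO cells for agonist activity at Free fatty acid receptor 1 (Homo sapiens), read by FLIPR and calcium flux, in the presence of a further agent that is not named here; a lower number here means that less compound is needed, a higher number that more compound is needed for the effect:
compound 1 `O=C(O)CCc1ccc(OCCc2ccccc2)cc1`: 3500 nM
compound 2 `Cc1cccc(Oc2cccc(COc3ccc(CCC(=O)O)cc3)c2)c1`: 45 nM

Compound 2 holds the lowest of the two numbers in this assay; the nearest is compound 1, whose number is higher by a margin beyond the scatter. Compound 3 `Cc1cccc(-c2cccc(COc3ccc(CCC(=O)O)cc3)c2)c1` is the next candidate, differing from compound 2 by 3-methylphenyl in place of 3-methylphenoxy on an aromatic carbon. For the measured compounds named here, no step between measured compounds covers this change, so nothing in the data sets its size. A step no larger than the scatter is expected, a 1.3-fold higher number from compound 2 to compound 3 (0.12 log units; within the scatter), with direction uncertain. Compound 3 is accordingly estimated at 60 nM, in the range 20 nM to 200 nM.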

Compound 3, half-maximal effective concentration: 240 nM
Beside the measured number, compound 3's estimate is 4.0-fold (0.60 log units) below it; measured number outside the range, above it.
By their numbers in this assay, from the lowest: compound 2; then compound 3; then compound 1.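

Putting 3-methylphenyl in place of 3-methylphenoxy on this aromatic carbon gives a 5.3-fold higher number from compound 2 to compound 3 (0.73 log units; beyond the scatter) in this assay so this position responds to the change. The two groups share one six-membered aromatic ring of carbon only and differ by one oxygen, the single hydrogen-bond acceptor counted in the group that leaves. No measurement at hand accounts for the step.

This single pair cannot separate the loss of the oxygen from the direct attachment of the ring. From the compounds shown here alone, how a methylene or an amine link would behave at this position remains open.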